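From compound 2 to compound 3: one group exchanged

This account rests on a few compounds, and the source may have more. Where it says the series, first, only, none or still open, it means among the compounds named here.

Compound 1 `COc1ccccc1-c1ccc2ncn(-c3cc(OC)c(OC)c(OC)c3)c2c1` gives 1750 nM in a functional assay on MCF7 cells (Homo sapiens) for antiproliferative activity, read by MTT assay, with a stated time of 72 h; a higher number here means a weaker inhibitor, a lower number a stronger inhibitor
Compound 2 `COc1cc(-n2cnc3ccc(-c4ccc(C(F)(F)F)cc4)cc32)cc(OC)c1OC` gives 760 nM in this assay

Compound 2 holds the lower of these two numbers, which makes it the stronger inhibitor of the pair. Compound 3 `COc1cc(-n2cnc3ccc(-c4cccc(C)c4C)cc32)cc(OC)c1OC` has not been measured yet. It keeps the core of compound 2 and exchanges one group, with 2,3-dimethylphenyl in place of 4-(trifluoromethyl)phenyl (2,3-dimethylphenyl in place of 4-(trifluoromethyl)phenyl on an aromatic carbon) on an aromatic carbon. Among the measured compounds shown here, only one measured step bears on this carbon: the swap from 2-methoxyphenyl to 4-(trifluoromethyl)phenyl gave a 2.3-fold lower number from compound 1 to compound 2 (0.36 log units; beyond the scatter) and counts as modest. For the measured compounds named here, no measured compound carries 2,3-dimethylphenyl, so a smaller change is expected in this assay with a slight lean towards a higher number and nothing clearly beyond the scatter. The expected change is a 1.4-fold higher number from compound 2 to compound 3 (0.16 log units; within the scatter) by this estimate. In this assay compound 3 is expected at 1100 nM with a range from 350 nM to 3000 nM as estimated.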

Compound 3, half-maximal inhibitory concentration: 2150 nM
Compound 3: middle estimate off by 2.0-fold (0.29 log units), on the low side; the measured number falls inside the stated range.
By their numbers in this assay, from the lowest: compound 2; then compounds 1 and 3 (each within the scatter of the next).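

In this assay, the exchange of 4-(trifluoromethyl)phenyl for 2,3-dimethylphenyl (a 2.8-fold higher number from compound 2 to compound 3 (0.45 log units; beyond the scatter)) shows that the lower number of compound 2 is not shared by every other substituted phenyl group on this carbon. The exchange of 2-methoxyphenyl for 2,3-dimethylphenyl (a 1.2-fold higher number from compound 1 to compound 3 (0.09 log units; within the scatter)) shows no difference that can be told from the scatter, so among these three groups only 4-(trifluoromethyl)phenyl stands apart. Nothing measured here accounts for that difference.

From the compounds shown here alone, whether the lower number goes with the trifluoromethyl group itself or with its place on the ring stays open, and a 4-methylphenyl or a 2-(trifluoromethyl)phenyl group would speak to that. Also open, going by these compounds, is how a phenyl group carrying an amine or a carboxylic acid would read at this carbon.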